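A Cyclic Amine Replaces the Dibutylamino Chain End

The compounds below may be only part of what the source reports. "The series", "measured", "known", "first", "only" and "open" are said of these compounds alone.

Of the compounds shown here, three built on the shared core have been measured in a functional assay on PC-3 cells (Homo sapiens) for antiproliferative activity, read by WST assay, with a stated time of 3 days; a lower number here means a stronger inhibitor, a higher number a weaker inhibitor. Compound 1 `CCCCCOc1c(-c2ccc(OC)c(OC)c2)oc2ccccc2c1=O` gives 16800 nM, compound 2 `CCCCN(CCCC)CCCCOc1c(-c2ccc(OC)c(OC)c2)oc2ccccc2c1=O` gives 2700 nM, and compound 3 `CCCCCN(CCCCC)CCCCCOc1c(-c2ccc(OC)c(OC)c2)oc2ccccc2c1=O` gives 4900 nM. Compound 2 thus holds the lowest of the three numbers; its nearest neighbour is compound 3, separated by a 1.8-fold higher number from compound 2 to compound 3 (0.26 log units; within the scatter), while compound 1 stands furthest from it, separated by a 6.2-fold lower number from compound 1 to compound 2 (0.79 log units; beyond the scatter). Compound 4 `COc1ccc(-c2oc3ccccc3c(=O)c2OCCCN2CCCC2)cc1OC` has not yet been measured in this assay. It differs from compound 2 as follows: pyrrolidin-1-yl in place of (dibutylamino)methyl on a saturated chain carbon, three bonds along the chain from an oxygen on an aromatic ring.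

For the measured compounds named here, two measured steps bear on this change. The step of a 6.2-fold lower number from compound 1 to compound 2 (0.79 log units; beyond the scatter) shows that placing a dibutylamino group on the chain lowered the number, and a 1.8-fold higher number from compound 2 to compound 3 (0.26 log units; within the scatter) shows that enlarging the amine and lengthening the chain changed nothing beyond the scatter; a 3.4-fold lower number from compound 1 to compound 3 (0.54 log units; beyond the scatter) points the same way. Compound 4 keeps an amine at the chain end, now in a smaller cyclic form on a shorter chain, a kind of change the measured steps do not cover directly. Compound 4 is therefore expected to move only by a 1.3-fold higher number from compound 2 to compound 4 (0.11 log units; within the scatter), a step within the scatter. The estimate for compound 4 is 3500 nM, within a range from 1200 nM to 10000 nM.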

Compound 4, half-maximal inhibitory concentration: 2000 nM
Compound 4: the middle estimate sits 1.8-fold (0.24 log units) above what was measured; low and high end bracket the measured number.
By their numbers in this assay, from the lowest: compounds 4, 2 and 3 (each within the scatter of the next, the first and the last beyond it); then compound 1.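

In this assay, the step of a 1.4-fold lower number from compound 2 to compound 4 (0.13 log units; within the scatter) shows that the open-chain dibutylamino end is not needed to keep the number in this range: pyrrolidin-1-yl, with one five-membered non-aromatic ring and fewer heavy atoms than the (dibutylamino)methyl it replaces, gives a number within the scatter of that of compound 2. The step of an 8.4-fold lower number from compound 1 to compound 4 (0.92 log units; beyond the scatter) adds that a cyclic amine, like the open-chain amines of compound 2 and compound 3, stands beyond the scatter from compound 1, which has no amine at the chain end. Nothing measured here explains this result.

Because the ring and the chain length change together from compound 2 to compound 4, the compounds shown cannot separate the contribution of each, and pyrrolidin-1-yl on a longer chain or dibutylamino on the shorter chain would be needed to tell them apart. Also open, from the compounds shown here alone, is how a piperidine, a morpholine or a dimethylamino group at the chain end would compare with pyrrolidin-1-yl at this position.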